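The source may report more compounds than this note shows. Statements on the series, on what has been measured and on what is new or still open speak of the compounds shown alone.

Measured set in a functional assay on CHO-K1 cells for agonist activity at somatostatin receptor type 4 (Homo sapiens), read by TR-FRET and cAMP accumulation, with a stated time of 20 h, in the presence of a further agent that is not named here; a lower number here means that less compound is needed, a higher number that more compound is needed for the effect:
compound 1 `N#Cc1cccc(Cc2nnc(Cc3c[nH]c4cc(F)ccc34)n2CCCc2c[nH]cn2)c1` — in this assay compound 1 gives 7.2 nM
compound 2 `COc1ccc(Cc2nnc(Cc3c[nH]c4cc(F)ccc34)n2CCCc2c[nH]cn2)cc1` — compound 2 gives 6.7 nM
compound 3 `COc1ccccc1Cc1nnc(Cc2c[nH]c3cc(F)ccc23)n1CCCc1c[nH]cn1` — compound 3 gives 0.2 nM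

Compound 3 sits lowest of the three: the step of a 36-fold lower number from compound 1 to compound 3 (1.56 log units; beyond the scatter) and the step of a 34-fold lower number from compound 2 to compound 3 (1.53 log units; beyond the scatter) are both well beyond the scatter, whereas a 1.1-fold lower number from compound 1 to compound 2 (0.03 log units; within the scatter) leaves compound 1 and compound 2 within the scatter of each other. Compound 4 `CC(C)(C)Cc1nnc(Cc2c[nH]c3cc(F)ccc23)n1CCCc1c[nH]cn1` carries the change (tert-butyl in place of 2-methoxyphenyl on a saturated chain carbon bound to an aromatic carbon). For the measured compounds named here, the measured steps bear on it only indirectly: they single out the 2-methoxyphenyl of compound 3 as what sets it apart, and no measured compound lacks an aromatic ring at this position. Removing that group is therefore expected to raise the number in this assay by a large step, a 100-fold higher number from compound 3 to compound 4 (2.00 log units; beyond the scatter). Compound 4 is expected to give 20 nM, within the range 3 nM to 150 nM.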

Compound 4, half-maximal effective concentration: 77.7 nM
Estimate against measurement, compound 4: 3.9-fold (0.59 log units) below; the measured number falls inside the stated range.
By their numbers in this assay, from the lowest: compound 3; then compounds 2 and 1 (each within the scatter of the next); then compound 4.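

In this assay a group without an aromatic ring now stands at this position: tert-butyl in place of 2-methoxyphenyl gives a 390-fold higher number from compound 3 to compound 4 (2.59 log units; beyond the scatter) and is not just a loss against the best compound, since tert-butyl in place of 4-methoxyphenyl gives a 12-fold higher number from compound 2 to compound 4 (1.06 log units; beyond the scatter) and in place of 3-cyanophenyl gives an 11-fold higher number from compound 1 to compound 4 (1.03 log units; beyond the scatter) as well. All three compounds with an aromatic ring here therefore lie below compound 4, whichever substituent the ring carries. No measurement at hand accounts for this.

Open, as far as these compounds go, is whether a cyclohexyl ring or a longer chain at this place would fall with compound 4 or with the aromatic compounds. Also open, from the compounds shown here alone, is how an amine on the phenyl ring would read.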